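The source may report more compounds than this note shows. Statements on the series, on what has been measured and on what is new or still open speak of the compounds shown alone.

In a functional assay on HCT-8 cells (Homo sapiens) for cytotoxicity (on this read-out lower numbers stand for an effect already at smaller amounts and higher numbers for an effect only at larger amounts of compound), compound 1 `COC1=C(C)C(=O)/C(=C(O)/C=C/c2cccc(OC)c2)C(=O)C1(C)C` gives 2.9 ug/mL and compound 2 `COC1=C(C)C(=O)/C(=C(O)/C=C/c2cc(C)cc(C)c2)C(=O)C1(C)C` gives 2.9 ug/mL so compound 2 stands level with compound 1. For the measured compounds named here, compound 3 `COC1=C(C)C(=O)/C(=C(O)/C=C/c2cccs2)C(=O)C1(C)C` departs from compound 2 by thiophen-2-yl in place of 3,5-dimethylphenyl on a double-bonded chain carbon bound to a double-bonded chain carbon and no measured compound yet carries thiophen-2-yl. Going by the values given here, the one measured step that bears on this change, no change at the digits printed from compound 1 to compound 2 (within the scatter) on the same chain carbon, lay within the scatter, so no step beyond the scatter is expected in this assay here. The expected outcome is a 1.0-fold higher number from compound 2 to compound 3 (0.01 log units; within the scatter) by this estimate. For compound 3 the estimated value is 3 ug/mL with 1.2 ug/mL to 7 ug/mL as the expected range.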

Compound 3, concentration for half-maximal effect: 8.6 ug/mL
Beside the measured number, compound 3's estimate is 2.9-fold (0.46 log units) below it; the measured number lies above the stated range.
By their numbers in this assay, from the lowest: compounds 1 and 2 (each within the scatter of the next); then compound 3.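

In this assay this place, on a double-bonded chain carbon bound to a double-bonded chain carbon, now shows a step beyond the scatter: thiophen-2-yl gives a 3.0-fold higher number from compound 2 to compound 3 (0.47 log units; beyond the scatter) and a 3.0-fold higher number from compound 1 to compound 3 (0.47 log units; beyond the scatter). For the compounds shown here, compound 1 and compound 2, both with a six-membered aromatic ring of carbon only, had stood level, so this is the first change here that moves the number. Nothing available explains this step. On these data alone, whether ring size or the sulfur atom goes with the step stays open, and so does how a furan-2-yl group or a phenyl ring carrying an amine would compare.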